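The source may hold more compounds than are shown below. What is called first, only, known or untested is meant among the compounds shown, and "the series" means these compounds.

Measured in an assay on frontal cortex for displacement of a labelled ligand from corticotropin-releasing factor receptor 1 (Rattus norvegicus); a higher number here means a weaker inhibitor, a lower number a stronger inhibitor:
Compound 1 `Cc1nc2c(cc1Nc1nc(Cl)cn([C@H](C)C3CC3)c1=O)COC2` gives 740 nM.
Compound 2 `CCOc1nc(C)c(Nc2nc(Cl)cn([C@H](C)C3CC3)c2=O)cc1C` gives 2.7 nM.
Compound 3 `Cc1cc(Nc2nc(Cl)cn([C@H](C)C3CC3)c2=O)c(C)nc1N(C)C` gives 0.68 nM.

Compound 3 has the lowest number of the three, with compound 2 nearest and compound 1 furthest away. Compound 4 `Cc1cc(Nc2nc(Cl)cn([C@H](C)C3CC3)c2=O)c(C)nc1N1CCCC1` differs from it in one place: pyrrolidin-1-yl in place of dimethylamino on an aromatic carbon. For the measured compounds named here, the only measured step at this position is a 4.0-fold lower number from compound 2 to compound 3 (0.60 log units; beyond the scatter), which swapped ethoxy for dimethylamino; no measured pair shows what happens when the dimethylamino is enlarged into a ring, so the data give no direct guide. Since both groups keep the same acceptor count and sit at the same place, compound 4 is expected to stay close to compound 3, with a step of a 1.0-fold higher number from compound 3 to compound 4 (0.01 log units; within the scatter) in this assay. Compound 4 is therefore estimated at 0.7 nM, within a range from 0.3 nM to 1.8 nM.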

Compound 4, half-maximal inhibitory concentration: 6.8 nM
The estimate for compound 4 lay 9.7-fold (0.99 log units) below the measured number; measured number above the stated range.
By their numbers in this assay, from the lowest: compound 3; then compound 2; then compound 4; then compound 1.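

In this assay, the position on the aromatic carbon next to the ring nitrogen responds strongly to closing an amine into a ring: pyrrolidin-1-yl in place of dimethylamino gives a 10-fold higher number from compound 3 to compound 4 (1.00 log units; beyond the scatter), though the hydrogen-bond acceptor count stays the same. Pyrrolidin-1-yl also falls behind ethoxy, with a 2.5-fold higher number from compound 2 to compound 4 (0.40 log units; beyond the scatter), so the order here from the lowest number is dimethylamino, ethoxy, pyrrolidin-1-yl. Nothing available explains these steps. Still open, going by these compounds, is how a four-membered azetidine ring, a six-membered piperidine ring or a morpholine ring would compare at this position. A longer open chain, such as diethylamino, is also untested among these compounds.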